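Sulfonamide aryl change in the shared core: clearance notes

This account rests on a few compounds, and the source may have more. Where it says the series, first, only, none or still open, it means among the compounds named here.

Measured compounds:
compound 1 `N#Cc1ccc(O[C@H]2CN(S(=O)(=O)c3ccc(Cl)cc3)C[C@@]2(O)CO)cc1F`: 1540 mL/min/kg
compound 2 `N#Cc1ccc(O[C@H]2CN(S(=O)(=O)c3ccc(C(F)(F)F)cc3)C[C@@]2(O)CO)cc1F`: 1500 mL/min/kg

In an ADME assay on the whole organism (Rattus norvegicus, strain Sprague-Dawley) for pharmacokinetics, read by LC-MS, with a stated time of 30 min, at a dose of 1 mg/kg by the intravenous route (on this read-out lower numbers stand for slow clearance and higher numbers for fast clearance), compound 1 gives 1540 mL/min/kg and compound 2 gives 1500 mL/min/kg; the two numbers are within the scatter of each other, so compound 2 stands level with compound 1. For the measured compounds named here, the one measured step, a 1.0-fold lower number from compound 1 to compound 2 (0.01 log units; within the scatter), is flat.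

Compound 3 `N#Cc1ccc(O[C@H]2CN(S(=O)(=O)c3ccc(C(F)(F)F)nc3)C[C@@]2(O)CO)cc1F` differs from compound 2 by 6-(trifluoromethyl)pyridin-3-yl in place of 4-(trifluoromethyl)phenyl on a sulfonyl sulfur. Going by the values given here, no measured step probes this change; the only step in hand, from compound 1 to compound 2, changed nothing beyond the scatter. Compound 3 is therefore expected to show no step beyond the scatter, a 1.1-fold lower number from compound 2 to compound 3 (0.03 log units; within the scatter). Compound 3 is estimated at 1400 mL/min/kg, with a range from 700 mL/min/kg to 2800 mL/min/kg.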

Compound 3, clearance: 210 mL/min/kg
Beside the measured number, compound 3's estimate is 6.7-fold (0.82 log units) above it; the measured number lies below the stated range.
By their numbers in this assay, from the lowest: compound 3; then compounds 2 and 1 (each within the scatter of the next).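

On the sulfonyl sulfur, the aryl ring itself matters in this assay, although chloro to trifluoromethyl on the phenyl ring stayed flat: the switch to 6-(trifluoromethyl)pyridin-3-yl gives a clear fall (a 7.1-fold lower number from compound 2 to compound 3 (0.85 log units; beyond the scatter)). Against 4-chlorophenyl the fall is of similar size (a 7.3-fold lower number from compound 1 to compound 3 (0.87 log units; beyond the scatter)), so among these three compounds the lower clearance goes only with the pyridine ring. No measurement in hand accounts for this fall. Still open, on these data alone, is whether the pyridine ring keeps this effect with chloro or methoxy in place of trifluoromethyl, and whether a pyrimidine ring goes further.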